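Exchanging the tert-butoxycarbonyl group of compound 1

The source may report more compounds than this note shows. Statements on the series, on what has been measured and on what is new or still open speak of the compounds shown alone.

Compound 1 (`CC(C)(C)OC(=O)N1CCC[C@H]1COCCCCCC/C=C/c1ccc(-c2ccccc2)cc1`) gives > 100000 nM in a functional assay on BXPC-3 cells (Homo sapiens) for inhibition, read by XTT assay, with a stated time of 72 h (on this read-out lower numbers stand for stronger inhibition and higher numbers for weaker inhibition), and this is a limit of the assay, not a number. For compound 1 that is all that can be said of its standing (the limit of > 100000 nM in this assay, at which 1 of the 3 values shown sits). Compound 2 (`CC(C)(C)OC(=O)N1CCC[C@H]1COCCCCCCCC/C=C/c1ccc(-c2ccccc2)cc1`) gives 70000 nM in this assay and compound 3 (`CC(C)(C)OC(=O)N1CCC[C@H]1COCCCCCC/C=C/c1ccc(Oc2ccccc2)cc1`) gives 63300 nM on the same read-out.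

Compound 4 (`Cc1ccc([S+]([O-])N2CCC[C@H]2COCCCCCC/C=C/c2ccc(-c3ccccc3)cc2)cc1`) departs from compound 1 on an amine nitrogen in a ring (a group of 9 heavy atoms (7 carbon, 1 oxygen, 1 sulfur; one six-membered aromatic ring of carbon only) in place of a group of 7 heavy atoms (5 carbon, 2 oxygen; no ring), on an amine nitrogen in a ring). There the tert-butoxycarbonyl group leaves, and a group with one six-membered aromatic ring of carbon only enters in its place.

Going by the values given here, the only measured step (an at least 1.5-fold lower number from compound 1 to compound 3 (0.19 log units; that floor lies within the scatter)) is phenoxy in place of phenyl on an aromatic carbon, and its floor lies within the scatter. That step does not touch the amine nitrogen, so no measurement speaks directly to this exchange. It gives only a weak guide to size, with compound 3 at 63300 nM as the nearest number. For compound 4 a small move to a lower number is therefore expected (an at least 2.2-fold lower number from compound 1 to compound 4 (0.34 log units; beyond the scatter)) and the assay may again report only a limit. Compound 4 is expected at 45000 nM (estimated range 12000 nM to 100000 nM).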

Compound 4, half-maximal inhibitory concentration: >= 100000 nM
Compound 4 ended at the assay's limit (the forecaster's own chance of this, stated with the estimate: 35%); middle value at least 2.2-fold (0.34 log units) from the limit.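

In this assay, compound 1 and compound 4 both ended at a limit rather than a number, so no step between them can be read: the limit of >= 100000 nM in this assay, at which 1 of the 4 values shown sits.

The compounds shown leave open whether the group replacing tert-butoxycarbonyl on the amine nitrogen in a ring changes inhibition at all, and in which direction.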